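The source may hold more compounds than are shown below. What is called first, only, known or untested is meant among the compounds shown, and "the series" means these compounds.

Measured in a functional assay on MDA-MB-435S cells (Homo sapiens) for cytotoxicity, read by MTT assay (on this read-out lower numbers stand for stronger inhibition and higher numbers for weaker inhibition), three compounds share one core and differ only in the side groups attached to it:

Compound 1 `CCOC(=O)COc1c(-c2ccc(OC)cc2)oc2c(CC=C(C)C)c(O)cc(O)c2c1=O` gives 30000 nM.
Compound 2 `COc1ccc(-c2oc3c(CC=C(C)C)c(OCCOC(=O)CCC(=O)O)cc(O)c3c(=O)c2OCCOC(=O)CCC(=O)O)cc1` gives 60500 nM.
Compound 3 `CCOC(=O)C(C)Oc1cc(O)c2c(=O)c(O)c(-c3ccc(OC)cc3)oc2c1CC=C(C)C` gives 2500 nM.

Compound 3 stands lowest of the three, meaning the strongest inhibition of cell growth in this set. Compound 1 is the nearest to it, yet its number is higher by a gap beyond the usual scatter; compound 2 sits further still, also beyond the scatter. So compound 3 is clearly the most potent compound among those measured.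

Compound 4 `CCOC(=O)COc1cc(O)c2c(=O)c(O)c(-c3ccc(OC)cc3)oc2c1CC=C(C)C` is the next compound, not yet measured. Compared with compound 3 it carries hydrogen in place of methyl on a saturated chain carbon bound to a carbonyl carbon and an oxygen on an aromatic ring. The side chain is thus shortened by a single carbon, and everything else in the molecule is kept. A change this small, at a flexible chain far from the ring system, gives no clear ground for a large shift. The step of a 1.4-fold higher number from compound 3 to compound 4 (0.15 log units; within the scatter) is expected to stay within the scatter, perhaps drifting slightly toward weaker inhibition. Compound 4 is therefore estimated at 3500 nM, with a plausible range from 1200 nM to 10000 nM.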

Compound 4, half-maximal inhibitory concentration: 5300 nM
For compound 4 the middle estimate is 1.5-fold (0.18 log units) below the measured one; the measured number falls inside the stated range.
By their numbers in this assay, from the lowest: compound 3; then compound 4; then compounds 1 and 2 (each within the scatter of the next).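

In this assay, taking the methyl off the saturated chain carbon bound to a carbonyl carbon and an oxygen on an aromatic ring gives a 2.1-fold higher number from compound 3 to compound 4 (0.33 log units; beyond the scatter), a modest step but one that clears the usual scatter. For the compounds shown here, this is the first comparison that isolates one place, and it shows that even one carbon at this spot, turning 1-(ethoxycarbonyl)ethoxy into (ethoxycarbonyl)methoxy, registers in the cell read-out, with the methyl-bearing compound 3 giving the lower number and so the stronger inhibition. Nothing available accounts for why this methyl makes a difference, so the step stands as an observation without an explanation.

One pair marks only two points at this position, so it cannot say whether the trend would continue with a longer chain such as ethyl or propyl on the same carbon, or whether the second methyl of a gem-dimethyl group would add anything further. It also leaves open how much of the activity depends on the ethyl ester itself, which a carboxylic acid or an amide in its place would test.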